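Adding phenoxy to a very strong inhibitor

A few compounds are considered here, and "the series" means these few. Any claim that something is new, unique, unknown or untested is made for them only; others in the source may bear on it.

In a functional assay on MCF7 cells (Homo sapiens) for inhibition (a higher number here means a weaker inhibitor, a lower number a stronger inhibitor), compound 1 (`Nc1ccc(-c2nc3ccccc3s2)cc1Cl`) gives < 0.1 nM, which is a limit of the assay and not a number. It therefore stands at the strong end of the values seen so far. Compound 2 (`COc1cccc2sc(-c3ccc(N)c(Cl)c3)nc12`) gives > 10000 nM, which is also a limit.

Compound 3 (`Nc1ccc(-c2nc3cc(Oc4ccccc4)ccc3s2)cc1Cl`) has not yet been measured in this assay. It keeps the core of compound 1 but carries one change: phenoxy in place of hydrogen on an aromatic carbon. In words, phenoxy takes the place of hydrogen on an aromatic carbon.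

Among the measured compounds shown here, only one measured step bears on this change, the replacement of hydrogen on an aromatic carbon by methoxy. That step was large and beyond the scatter. A move toward weaker inhibition is expected because an at least 100000-fold higher number from compound 1 to compound 2 (5.00 log units; beyond the scatter) was seen with that replacement. However, this is a single step involving a different group, so the size of the new step remains uncertain. The expected step is an at least 1000-fold higher number from compound 1 to compound 3 (3.00 log units; beyond the scatter), which would still be large. The estimated value for compound 3 is 100 nM, with an expected range from 1 nM to 10000 nM.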

Compound 3, half-maximal inhibitory concentration: > 10000 nM
Compound 3: a limit, no number (the forecaster's own chance of this, stated with the estimate: 35%); middle value at least 100-fold (2.00 log units) from the limit.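

In this assay, phenoxy on this aromatic carbon brings an at least 100000-fold higher number from compound 1 to compound 3 (5.00 log units; beyond the scatter). Compound 2 carries methoxy on a different aromatic carbon of the same ring, so the very strong inhibition of compound 1 has now been lost at two places on that ring and with two different groups, and no compound shown goes against this. The step is only a minimum, since both of its ends are limits of the assay and not numbers, and the weak limit is now shared by two compounds: the limit of > 10000 nM in this assay, at which 2 of the 3 values shown sit.

On these data alone, how far past that limit compound 3 really lies stays unknown, and the shared limit gives no way to rank phenoxy against methoxy. Also open, as far as these compounds go, is whether a much smaller group on this aromatic carbon, such as fluorine or a hydroxyl, would keep the inhibition seen with hydrogen in compound 1, or whether any replacement of that hydrogen is enough to lose it.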